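A few compounds are considered here, and "the series" means these few. Any claim that something is new, unique, unknown or untested is made for them only; others in the source may bear on it.

Compound 3 `CN(C(=O)NC(=O)c1ccccc1)c1nc(C(F)(F)F)c(C(=O)N/N=C/c2cccc([N+](=O)[O-])c2)s1` holds the higher of the two numbers measured in a functional assay on HepG2 cells (Homo sapiens) for inhibition, read by MTT assay, with a stated time of 72 h; a lower number here means a stronger inhibitor, a higher number a weaker inhibitor: compound 3 gives 14.3 ug/mL. Compound 2 `CN(C(=O)NC(=O)c1ccc(Cl)c(Cl)c1)c1nc(C(F)(F)F)c(C(=O)N/N=C/c2ccc([N+](=O)[O-])cc2)s1` gives 6.85 ug/mL, a gap beyond the usual scatter. Compound 1 `CNc1nc(C(F)(F)F)c(C(=O)N/N=C/c2cccc(C(F)(F)F)c2)s1` gives only a limit in this assay, > 100 ug/mL. That is the limit of > 100 ug/mL in this assay, at which 1 of the 3 values shown sits. Compound 4 `CN(C(=O)NC(=O)c1ccc(Cl)c(Cl)c1)c1nc(C(F)(F)F)c(C(=O)N/N=C/c2cccc([N+](=O)[O-])c2)s1` differs from compound 3 in one place: 3,4-dichlorophenyl in place of phenyl on a carbonyl carbon. Among the measured compounds shown here, no measured pair shows this change on its own, so its size is uncertain; a moderate gain in potency is expected, since compound 2, which also carries the 3,4-dichlorophenyl group, gave 6.85 ug/mL. For compound 4 the expected value in this assay is 8 ug/mL, between 4 ug/mL and 20 ug/mL, an expected step of a 1.8-fold lower number from compound 3 to compound 4 (0.25 log units; within the scatter).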

Compound 4, half-maximal inhibitory concentration: 7.98 ug/mL
Beside the measured number, compound 4's estimate is 1.0-fold (0.00 log units) above it; the measured number falls inside the stated range.
By their numbers in this assay, from the lowest: compounds 2, 4 and 3 (each within the scatter of the next, the first and the last beyond it). At a limit, above all of these: compound 1.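

In this assay, 3,4-dichlorophenyl in place of phenyl on the carbonyl carbon gives a 1.8-fold lower number from compound 3 to compound 4 (0.25 log units; within the scatter), so this first direct reading of the change does not set the two compounds apart. 3-Nitrophenyl in place of 4-nitrophenyl on a carbon with a double bond to nitrogen gives a 1.2-fold higher number from compound 2 to compound 4 (0.07 log units; within the scatter), and these two compounds cannot be told apart either. Nothing shown here accounts for either step. As far as these compounds go, whether a methoxy group in place of the two chlorines, or a pyridine ring in place of the phenyl, would move the number beyond the scatter remains open.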